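Swapping fluoro for chloro on a second prenylated core

The source may report more compounds than this note shows. Statements on the series, on what has been measured and on what is new or still open speak of the compounds shown alone.

Of the compounds shown here, three built on one shared core have been tested in a functional assay on PANC-1 cells (Homo sapiens) for inhibition, read by MTT assay, with a stated time of 24 h, tested at 10 uM; on this read-out lower numbers stand for less inhibition and higher numbers for more inhibition at the one concentration tested (going by the name of the read-out). Compound 1 `CC(C)=CCC1Cc2c(OC(=O)Nc3ccc(F)c(F)c3)cc(=O)n(CCCO)c2CC1(C)C` gives 76.7%. Compound 2 `CC(C)=CCC1Cc2c(OC(=O)Nc3ccc(F)c(Cl)c3)cc(=O)n(CCCO)c2CC1(C)C` gives 79.8%. Compound 3 `CC(C)=CCC/C(C)=C/CC1Cc2c(OC(=O)Nc3ccc(F)c(F)c3)cc(=O)n(CCCO)c2CC1(C)C` gives 43.7%, the lowest of the three.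

The change from compound 1 to compound 2 is chloro in place of fluoro on an aromatic carbon, and it made a number 3.1 percentage points higher from compound 1 to compound 2 (within the scatter). The core of compound 3 differs from that of compound 1 by 3-methylbut-2-en-1-yl in place of hydrogen on a saturated chain carbon bound to a double-bonded chain carbon, which made a number 33 percentage points lower from compound 1 to compound 3 (beyond the scatter).

Compound 4 `CC(C)=CCC/C(C)=C/CC1Cc2c(OC(=O)Nc3ccc(F)c(Cl)c3)cc(=O)n(CCCO)c2CC1(C)C` has not yet been measured. It differs from compound 3 by chloro in place of fluoro on an aromatic carbon, the same change as from compound 1 to compound 2, at the same place. Because a number 3.1 percentage points higher from compound 1 to compound 2 (within the scatter) stayed within the scatter, a step of similar size is expected from compound 3 to compound 4, about a number 3.3 percentage points higher from compound 3 to compound 4 (within the scatter). This rests on a single earlier pair, so the expectation is uncertain. Compound 4 is estimated to give 47%, with a range from 32% to 62%.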

Compound 4, a percentage reported as inhibition, at one concentration (the size of the read-out at that concentration, not a potency): 25%
Compound 4: the middle estimate sits 22 percentage points above what was measured, outside the stated range (below it).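

Chloro in place of fluoro made a number 18.7 percentage points lower from compound 3 to compound 4 (beyond the scatter) in this assay, so this change did not carry over from the core of compound 1 to the core of compound 3: the same change on two cores in this assay, a number 3.1 percentage points higher (within the scatter) from compound 1 to compound 2 and a number 18.7 percentage points lower (beyond the scatter) from compound 3 to compound 4, 21.8 percentage points apart, beyond the scatter of two such steps

Read the other way, 3-methylbut-2-en-1-yl in place of hydrogen made a number 54.8 percentage points lower from compound 2 to compound 4 (beyond the scatter), so the size of this step also depends on which halogen the aromatic ring carries: the same change on two cores in this assay, a number 33 percentage points lower (beyond the scatter) from compound 1 to compound 3 and a number 54.8 percentage points lower (beyond the scatter) from compound 2 to compound 4, 21.8 percentage points apart, beyond the scatter of two such steps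

The two changes therefore do not simply add up across these four compounds, but this rests on a single pair for each core at one concentration, and it does not show why the two changes interact.

The compounds shown leave open whether another group on that aromatic carbon, such as bromo or methyl, would follow the drop seen on the core of compound 3 or the step within the scatter seen on the core of compound 1. Also open, as far as these compounds go, is how the two halogens would compare with a saturated alkyl chain in place of 3-methylbut-2-en-1-yl.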